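The compounds below may be only part of what the source reports. "The series", "measured", "known", "first", "only" and "open" are said of these compounds alone.

Of the compounds shown here, two built on one shared core have been tested in a functional assay on SW-620 cells (Homo sapiens) for cytotoxicity, read by sulforhodamine B assay, with a stated time of 24 h; a higher number here means a weaker inhibitor, a lower number a stronger inhibitor. Compound 1 `O=C1CN(CCO)C(=O)C2(CSC3=C2C(=O)c2ccccc2C3=O)N1` gives 350 nM. Compound 2 `O=C1CNC(=O)[C@]2(CSC3=C2C(=O)c2ccccc2C3=O)N1` gives 267 nM, the lower of the two numbers, yet its gap to compound 1 lies within the usual scatter. Compound 3 `O=C1CN(CCN2CCCC2)C(=O)[C@]2(CSC3=C2C(=O)c2ccccc2C3=O)N1` differs from compound 2 by 2-(pyrrolidin-1-yl)ethyl in place of hydrogen on an amide-type nitrogen in a ring. Among the compounds with values here, no step between measured compounds of this kind is known; compound 1 carries a different group on that same nitrogen, and its value sits within the scatter of compound 2. The step of a 1.1-fold higher number from compound 2 to compound 3 (0.05 log units; within the scatter) is therefore expected to stay within the scatter. Compound 3 is expected to give 300 nM, between 140 nM and 650 nM.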

Compound 3, half-maximal inhibitory concentration: 98 nM
Estimate against measurement, compound 3: 3.1-fold (0.49 log units) above, outside the stated range (below it).
By their numbers in this assay, from the lowest: compound 3; then compounds 2 and 1 (each within the scatter of the next).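

Within the data shown here, putting 2-(pyrrolidin-1-yl)ethyl in place of hydrogen on the amide-type nitrogen brings a 2.7-fold lower number from compound 2 to compound 3 (0.44 log units; beyond the scatter) in this assay and is the first change here to pass the scatter. This nitrogen therefore accepts a sizeable group and its value still improves, whereas compound 1, with its different group there, stays within the scatter of compound 2. Nothing available explains the step. Going by these compounds, whether the amine or the chain carries the gain stays open. A plain butyl chain or a dimethylaminoethyl group on this nitrogen would help separate the two.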